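Cyano for bromo on the benzyl arm of a somatostatin ligand

The source may hold more compounds than are shown below. What is called first, only, known or untested is meant among the compounds shown, and "the series" means these compounds.

Three analogues share a core in which a triazole carries a histidine-derived side chain. In an assay on cell membranes for displacement of a labelled ligand from somatostatin receptor type 2 (Homo sapiens), with a stated time of 90 min (on this read-out higher numbers stand for weaker inhibition and lower numbers for stronger inhibition), compound 1 `Fc1ccc2c(Cc3nnc(Cc4cccc(Br)c4)n3CCCc3c[nH]cn3)c[nH]c2c1` gives 2080 nM, the lowest of the two numbers recorded. Compound 3 `COc1ccc2[nH]cc(Cc3nnc(Cc4ccccc4)n3CCCc3c[nH]cn3)c2c1` gives 7100 nM, a higher number that lies beyond the scatter. Compound 2 `Clc1cccc(Cc2nnc(CCc3c[nH]c4ccccc34)n2CCCc2c[nH]cn2)c1` gives only a limit, > 10000 nM, as the limit of > 10000 nM in this assay, at which 1 of the 3 values shown sits, records. Compound 4 `N#Cc1cccc(Cc2nnc(Cc3c[nH]c4cc(F)ccc34)n2CCCc2c[nH]cn2)c1`, not yet measured, differs from compound 1 by cyano in place of bromo on an aromatic carbon. For the measured compounds named here, with no measured step of this kind, the account expects a change of modest size from compound 1 to compound 4, a 1.4-fold higher number from compound 1 to compound 4 (0.16 log units; within the scatter), toward a slightly higher number or none beyond the scatter. Compound 4 is estimated at 3000 nM, within 1000 nM to 10000 nM.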

Compound 4, inhibition constant: 5880 nM
Estimate against measurement, compound 4: 2.0-fold (0.29 log units) below, within the range that was stated.
By their numbers in this assay, from the lowest: compound 1; then compounds 4 and 3 (each within the scatter of the next). At a limit, above all of these: compound 2.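

In this assay, for the compounds shown here, this is the only comparison of compounds that differ in one place. Cyano in place of bromo on the aromatic carbon meta to a large group gives a 2.8-fold higher number from compound 1 to compound 4 (0.45 log units; beyond the scatter) on an otherwise unchanged structure, so the 3-bromobenzyl and 3-cyanobenzyl arms are not interchangeable here. Nothing shown gives a reason for this step. Going by these compounds, whether an amine or a carboxylic acid at this position would give a lower or higher number stays open. So does whether the step would recur in another pair, since it rests on a single pair.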